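Swapping 4-chlorophenyl for 2,4-dimethylphenyl on a sulfonamide nitrogen

The source may report more compounds than this note shows. Statements on the series, on what has been measured and on what is new or still open speak of the compounds shown alone.

Among the measured compounds shown here, in a functional assay on MCF7 cells (Homo sapiens) for antiproliferative activity, read by sulforhodamine B assay, with a stated time of 48 h (a higher number here means a weaker inhibitor, a lower number a stronger inhibitor), compound 1 `O=C1NCCN1c1ccc(S(=O)(=O)Nc2ccc(I)cc2)cc1` gives 600 nM and compound 2 `O=C1NCCN1c1ccc(S(=O)(=O)Nc2ccc(Cl)cc2)cc1` gives 170 nM which is the lower of the two numbers measured so far. The change between them, chloro in place of iodo on an aromatic carbon, is a 3.5-fold lower number from compound 1 to compound 2 (0.55 log units; beyond the scatter) and counts as modest.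

Compound 3 `Cc1ccc(NS(=O)(=O)c2ccc(N3CCNC3=O)cc2)c(C)c1` has not yet been measured. It carries 2,4-dimethylphenyl in place of 4-chlorophenyl on a sulfonamide nitrogen so the whole group changes rather than a single atom. For the measured compounds named here, only one measured comparison bears on this. Compound 1 stands at 600 nM and shows that a different group on that same sulfonamide nitrogen gave a higher number than compound 2 did. Going by the values given here, a single comparison is thin evidence, and none of the measured compounds carries methyl groups. A modest rise is still the likeliest outcome, and the expected size is a 2.4-fold higher number from compound 2 to compound 3 (0.37 log units; beyond the scatter) in this assay with real uncertainty around it. For compound 3 the estimated value is 400 nM with an expected range of 90 nM to 1800 nM for repeated measurements.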

Compound 3, half-maximal inhibitory concentration: 230 nM
Compound 3: the middle estimate sits 1.7-fold (0.24 log units) above what was measured; low and high end bracket the measured number.
By their numbers in this assay, from the lowest: compounds 2 and 3 (each within the scatter of the next); then compound 1.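

In this assay, the whole group on the sulfonamide nitrogen can change without a clear shift in the number: 2,4-dimethylphenyl in place of 4-chlorophenyl gives a 1.4-fold higher number from compound 2 to compound 3 (0.13 log units; within the scatter), so compound 2 and compound 3 cannot be told apart. Compound 3 contains no halogen, which shows that a chlorine or iodine on this ring is not needed for a number in this range, and that two methyl groups can stand on the ring with no clear loss compared with compound 2. The same group in place of 4-iodophenyl gives a 2.6-fold lower number from compound 1 to compound 3 (0.42 log units; beyond the scatter), so among these three compounds only compound 1 stands apart, and nothing given here explains this pattern.

Going by these compounds, it remains open whether the ring tolerates very different groups, such as an amine or a carboxylic acid, or whether a longer carbon chain could replace the ring altogether. The compounds shown also leave open how a ring with a single methyl group would compare with compound 3, so the separate contribution of each methyl group is unknown.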